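Swapping a spirocyclic amine for a fused pyrrole-containing amine

This account rests on a few compounds, and the source may have more. Where it says the series, first, only, none or still open, it means among the compounds named here.

Measured compounds:
- compound 1 `COc1ccc2[nH]c(C(=O)N3CC(=O)N(Cc4ccccc4)[C@@H](CN4CCC5(CC4)CC5)C3)cc2c1`: 28200 nM
- compound 2 `O=C(c1cc2cc(C3CC3)ccc2[nH]1)N1CC(=O)N(Cc2ccccc2)[C@@H](CN2CCC(F)CC2)C1`: 12400 nM
- compound 3 `COc1ccc2[nH]c(C(=O)N3CC(=O)N(Cc4ccc[nH]4)[C@@H](Cc4ccccc4)C3)cc2c1`: 38400 nM

All three were examined in a physicochemical assay for solubility, read by spectrophotometry, in phosphate buffer, with a stated time of 2 h, at pH 7.4; on this read-out higher numbers stand for higher solubility and lower numbers for lower solubility. Compound 1 gives 28200 nM, the second highest of the three numbers. Compound 3 gives 38400 nM, which lies within the scatter of compound 1, so the two cannot be told apart. Compound 2 gives 12400 nM, a lower number than compound 1 and beyond the scatter; compound 2 differs from compound 1 in more than one place, so nothing further is drawn from that pair.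

Compound 4 `COc1ccc2[nH]c(C(=O)N3CC(=O)N(Cc4ccccc4)[C@@H](CN4CCn5cccc5C4)C3)cc2c1` has not yet been measured in this assay. It differs from compound 1 by a group of 9 heavy atoms (7 carbon, 2 nitrogen; one five-membered aromatic ring with 1 hetero atom, one six-membered non-aromatic ring with 2 hetero atoms) in place of a group of 8 heavy atoms (7 carbon, 1 nitrogen; one three-membered non-aromatic ring of carbon only, one six-membered non-aromatic ring with 1 hetero atom), on a saturated chain carbon bound to a saturated ring carbon. Among the compounds with values here, no measured pair shows this kind of change, so the expectation rests only on the spread of the three numbers seen. Only a small step in either direction is expected, with no direction favoured. The expected step is a 1.2-fold higher number from compound 1 to compound 4 (0.07 log units; within the scatter). On that basis compound 4 is estimated at 33000 nM, in a range from 13000 nM to 85000 nM.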

Compound 4, solubility: 29700 nM
Compound 4: the middle estimate sits 1.1-fold (0.05 log units) above what was measured; measured number inside the range.
By their numbers in this assay, from the lowest: compound 2; then compounds 1, 4 and 3 (each within the scatter of the next).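

Within the data shown here, this is the first comparison in the set that isolates a single position, the saturated chain carbon bound to a saturated ring carbon. In this assay, replacing the group with a three-membered carbon ring by the group with a five-membered aromatic ring gives a 1.1-fold higher number from compound 1 to compound 4 (0.02 log units; within the scatter) and so compound 1 and compound 4 cannot be told apart. At this position and on this core, then, a change in ring make-up and in the count of hetero atoms leaves no readable mark on the number, and nothing available offers an explanation for this result.

This single exchange does not show how other groups would fare at the same carbon. A morpholine or a carboxylic acid there could still move the number beyond the scatter, and the compounds shown do not settle this.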